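This account rests on a few compounds, and the source may have more. Where it says the series, first, only, none or still open, it means among the compounds named here.

Three compounds built on one shared core have been examined in an assay on a protein complex for inhibition of CDK8/Cyclin C (Homo sapiens), with a stated time of 1 h, tested at 10 uM; on this read-out higher numbers stand for more inhibition at the one concentration tested (going by the name of the read-out) and lower numbers for less inhibition. Compound 1 `CNC(=O)/C=C/c1ccncc1-c1ccc2ccccc2c1` gives 101%, compound 2 `O=C(O)COc1ccncc1-c1ccc2ccccc2c1` gives 16%, and compound 3 `CNC(=O)CCc1ccncc1-c1ccc2ccccc2c1` gives 100%. On these numbers compound 3 sits alongside compound 1, the pair being separated only by a number 1 percentage points lower from compound 1 to compound 3 (within the scatter), and far above compound 2, as shown by a number 84 percentage points higher from compound 2 to compound 3 (beyond the scatter).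

Compound 4 `COC(=O)/C=C/c1ccncc1-c1ccc2ccccc2c1` is the next member of the series. Its change from compound 3 is 2-(methoxycarbonyl)ethenyl in place of 2-(methylcarbamoyl)ethyl on an aromatic carbon. Among the measured compounds shown here, two measured steps bear on it. The first, a number 1 percentage points lower from compound 1 to compound 3 (within the scatter), shows that the double bond of the chain can be present or absent without any effect beyond the scatter, so the double bond entering with compound 4 is not expected to matter on its own. The second, a number 85 percentage points lower from compound 1 to compound 2 (beyond the scatter), shows that replacing the methylcarbamoyl-bearing chain with carboxymethoxy costs almost all of the inhibition, but carboxymethoxy is a different group from the ester entering here, so this step gives only a caution that altering the chain head can be costly. For the measured compounds named here, no measured step exchanges an amide for an ester.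

Compound 4 is therefore expected to give 70% in this assay, with a range from 25% to 100%. Against compound 3 this estimate means an expected a number 30 percentage points lower from compound 3 to compound 4 (beyond the scatter).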

Compound 4, a percentage reported as inhibition, at one concentration (the size of the read-out at that concentration, not a potency): 102%
The estimate for compound 4 lay 32 percentage points below the measured number; the whole stated range lies below it.
By their numbers in this assay, from the lowest: compound 2; then compounds 3, 1 and 4 (each within the scatter of the next).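

In this assay, among the compounds shown here, the direct exchange of the amide for the ester on the ethenyl chain, methoxy in place of methylamino on a carbonyl carbon, gives a number 1 percentage points higher from compound 1 to compound 4 (within the scatter) and so shows for the first time that this position accepts a chain head with 0 hydrogen-bond donors in place of one with 1 hydrogen-bond donor without a change beyond the scatter. The wider exchange gives a number 2 percentage points higher from compound 3 to compound 4 (within the scatter) with the double bond and the ester entering together, while a number 86 percentage points higher from compound 2 to compound 4 (beyond the scatter) shows that the ester chain stays as far above carboxymethoxy as the two amide chains do, so a change of chain head at this position is not costly in every case. Nothing measured here explains why the ester and the amide read alike.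

All three chain compounds lie close together at the one concentration tested, so this read-out cannot show whether their potencies differ at lower concentrations. It also leaves open how this position would respond to an amine or a nitrile at the head of the chain, or to a longer chain.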